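This account rests on a few compounds, and the source may have more. Where it says the series, first, only, none or still open, it means among the compounds named here.

Going by the values given here, compound 2 `O=[N+]([O-])c1ccc(S(=O)(=O)N2CC(n3cnc4c(Cl)ncnc43)OCc3ccccc32)cc1` is the only compound in this small set with an actual number: in a functional assay on MCF7 cells (Homo sapiens) for antiproliferative activity (on this read-out higher numbers stand for weaker inhibition and lower numbers for stronger inhibition), compound 2 gives 2730 nM. Compound 1 `O=[N+]([O-])c1ccc(S(=O)(=O)N2CC(n3cnc4ncnc(O)c43)OCc3ccccc32)cc1` reaches only a limit of the assay, giving > 100000 nM in this assay. Among the compounds with values here, the one measured step, an at least 36-fold lower number from compound 1 to compound 2 (1.56 log units; beyond the scatter), swaps one bicyclic group for another on the saturated ring carbon, and it is large; compound 1 sits at the limit of > 100000 nM in this assay, at which 1 of the 2 values shown sits. Compound 3 `O=c1cc[nH]c(=O)n1C1CN(S(=O)(=O)c2ccc([N+](=O)[O-])cc2)c2ccccc2CO1` is the compound not yet measured. Against compound 2 the change is a group of 8 heavy atoms (4 carbon, 2 nitrogen, 2 oxygen; one six-membered aromatic ring with 2 hetero atoms) in place of a group of 10 heavy atoms (5 carbon, 4 nitrogen, 1 chlorine; one five-membered aromatic ring with 2 hetero atoms, one six-membered aromatic ring with 2 hetero atoms), on a saturated ring carbon, placed next to the ring oxygen and two ring bonds from the ring nitrogen. Within the data shown here, the only step that bears on this change is an at least 36-fold lower number from compound 1 to compound 2 (1.56 log units; beyond the scatter), a swap of the same kind of group at the same carbon that moved the number a great deal, so a sizeable step is expected in this assay here too, toward a higher number. Compound 3 is therefore estimated at about 30000 nM, with a range from 5000 nM to 150000 nM. That estimate amounts to an expected step of an 11-fold higher number from compound 2 to compound 3 (1.04 log units; beyond the scatter).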

Compound 3, half-maximal inhibitory concentration: 44300 nM
Compound 3: middle estimate off by 1.5-fold (0.17 log units), on the low side; the measured number falls inside the stated range.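

On the saturated ring carbon next to the ring oxygen, a second replacement of the chlorine-bearing group also costs much in this assay, with a 16-fold higher number from compound 2 to compound 3 (1.21 log units; beyond the scatter), so the loss seen with compound 1 is not confined to one group. The group with a single six-membered aromatic ring can still be told apart from the bicyclic group of compound 1, with an at least 2.2-fold lower number from compound 1 to compound 3 (0.35 log units; beyond the scatter), and so this carbon now ranks three groups, with the chlorine-bearing group of compound 2 giving the lowest number. Compound 1 remains a limit of the assay, so the true size of that step stays unknown: the limit of > 100000 nM in this assay, at which 1 of the 3 values shown sits.

The compounds shown leave open whether the chlorine itself matters or the bicyclic group around it, and whether an amine or a methoxy group in place of the chlorine would keep the number of compound 2. They also leave open how the number would move if the nitro group shared by all three gave way to a nitrile or an amine.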